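This account rests on a few compounds, and the source may have more. Where it says the series, first, only, none or still open, it means among the compounds named here.

Compound 1 `O=c1ccc2cc(OCc3cc(-c4ccccc4)no3)ccc2o1`, 53200 nM in a functional assay on PC-3 cells (Homo sapiens) for cytotoxicity, read by MTT assay, with a stated time of 48 h; on this read-out higher numbers stand for weaker inhibition and lower numbers for stronger inhibition; compound 2 `O=c1ccc2cc(OCc3cc(-c4cccc(Cl)c4)no3)ccc2o1`, "not determined" (no result reported) in this assay (no result reported); compound 3 `O=c1ccc2cc(OCc3cc(-c4ccccc4[N+](=O)[O-])no3)ccc2o1`, 8200 nM in this assay.

Among the compounds with values here, of the two numbers obtained, compound 3 stands lowest, and the single measured step, a 6.5-fold lower number from compound 1 to compound 3 (0.81 log units; beyond the scatter), is the one that brought the nitro in. Compound 4 `N#Cc1ccccc1-c1cc(COc2ccc3oc(=O)ccc3c2)on1` differs from compound 3 by cyano in place of nitro on an aromatic carbon. Within the data shown here, no step from nitro to cyano has been measured here; the only step that bears on it, a 6.5-fold lower number from compound 1 to compound 3 (0.81 log units; beyond the scatter), shows that the nitro itself is worth a modest gain, so removing it in favour of cyano is expected to give back part of that gain. Compound 4 is therefore estimated at 14000 nM, with a range from 5000 nM to 40000 nM, which corresponds to an expected 1.7-fold higher number from compound 3 to compound 4 (0.23 log units; within the scatter).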

Compound 4, half-maximal inhibitory concentration: 13600 nM
Estimate against measurement, compound 4: 1.0-fold (0.01 log units) above; low and high end bracket the measured number.
By their numbers in this assay, from the lowest: compounds 3 and 4 (each within the scatter of the next); then compound 1.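

The step of a 1.7-fold higher number from compound 3 to compound 4 (0.22 log units; within the scatter) lies within the scatter, so in this assay nitro and cyano cannot be told apart at this place, ortho to a large group. The gain over the unsubstituted phenyl of compound 1 is therefore not unique to nitro, as the step of a 3.9-fold lower number from compound 1 to compound 4 (0.59 log units; beyond the scatter) lies beyond the scatter. No measurement here explains why these two groups give similar results. On these data alone, whether an amine or a carboxylic acid at this place would keep the gain remains open.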